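The source may report more compounds than this note shows. Statements on the series, on what has been measured and on what is new or still open speak of the compounds shown alone.

Going by the values given here, compound 1, with the structure `COc1cc(C)cc(-c2c(-c3ccnc(-c4ccc(N(C)C)cc4)c3)cnn2CC#N)c1`, is one of two compounds measured in a functional assay on KM12 cells (Homo sapiens) for cytotoxicity, read by sulforhodamine B assay, with a stated time of 48 h, tested at 1 uM; on this read-out higher numbers stand for a weaker effect at the one concentration tested and lower numbers for a stronger effect; compound 1 gives -43%, the lowest of the two numbers, while compound 2 `Cc1cc(O)cc(-c2nn(CC#N)cc2-c2ccnc(-c3ccc(N(C)C)cc3)c2)c1` gives -9%, a gap beyond the usual scatter. Compound 3 `COc1cc(C)cc(-c2c(-c3ccnc(-c4ccc(C(C)=O)cc4)c3)cnn2CC#N)c1` has not been measured yet. It differs from compound 1 in one place: acetyl in place of dimethylamino on an aromatic carbon. Among the compounds with values here, no measured pair shows what this change does, so in this assay a step of modest size, in either direction, is expected. Compound 3 is estimated at -30%, between -60% and 0%. The expected step is a number 13 percentage points higher from compound 1 to compound 3 (beyond the scatter).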

Compound 3, a percentage reported as activity, at one concentration (the size of the read-out at that concentration, not a potency): 9%
Estimate against measurement, compound 3: 39 percentage points below; the whole stated range lies below it.
By their numbers in this assay, from the lowest: compound 1; then compound 2; then compound 3.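

In this assay, placing acetyl instead of dimethylamino on this aromatic carbon gives a number 52 percentage points higher from compound 1 to compound 3 (beyond the scatter), so the group at this position strongly shapes the effect. The two groups have the same counts of heavy atoms, hydrogen-bond donors and hydrogen-bond acceptors, so those counts alone do not settle the outcome. No available evidence explains the difference. The compounds shown leave open how a smaller amine, such as methylamino, or a larger one, such as diethylamino, would behave here. A carboxylic acid at this position also remains an open case.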